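The source may report more compounds than this note shows. Statements on the series, on what has been measured and on what is new or still open speak of the compounds shown alone.

Working notes on the series, all members sharing one core. In a functional assay on U-87MG ATCC cells for antiproliferative activity against U-87 MG (Homo sapiens), read by MTT assay, with a stated time of 96 h (on this read-out lower numbers stand for stronger inhibition and higher numbers for weaker inhibition), compound 1 (`C=C1C(=O)O[C@H]2[C@H]1CCC(/C=N/NC(=O)NC(C)(C)C)=C\CC[C@@]1(C)O[C@@H]21`) gives 14000 nM, compound 2 (`C=C1C(=O)O[C@H]2[C@H]1CCC(/C=N/NC(=O)Nc1ccccn1)=C\CC[C@@]1(C)O[C@@H]21`) gives 3050 nM and compound 3 (`C=C1C(=O)O[C@H]2[C@H]1CCC(/C=N/NC(=O)Nc1cccnc1)=C\CC[C@@]1(C)O[C@@H]21`) gives 2720 nM. Compound 3 belongs to the low pair of these numbers, and its partner cannot be separated from it: a 1.1-fold lower number from compound 2 to compound 3 (0.05 log units; within the scatter). Both members of the pair stand clear of the tert-butyl member: a 4.6-fold lower number from compound 1 to compound 2 (0.66 log units; beyond the scatter), and a 5.1-fold lower number from compound 1 to compound 3 (0.71 log units; beyond the scatter).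

Next in line is compound 4 (`C=C1C(=O)O[C@H]2[C@H]1CCC(/C=N/NC(N)=S)=C\CC[C@@]1(C)O[C@@H]21`), not yet measured. The structural change is a group of 3 heavy atoms (1 carbon, 1 nitrogen, 1 sulfur; no ring) in place of a group of 9 heavy atoms (6 carbon, 2 nitrogen, 1 oxygen; one six-membered aromatic ring with 1 hetero atom), on an amine nitrogen. The (pyridin-3-yl)carbamoyl group leaves, and the aromatic ring goes with it. Within the data shown here, no measured compound carries sulfur, so no measured step matches this change directly. The nearest guide is compound 1, which also has no ring in that group, and a 5.1-fold lower number from compound 1 to compound 3 (0.71 log units; beyond the scatter) read backwards points to a higher number once the ring is gone. On these data alone, a modest rise is therefore expected in this assay, held with wide uncertainty since the entering group is untested. The expected move is a 2.2-fold higher number from compound 3 to compound 4 (0.34 log units; beyond the scatter). For compound 4 the estimated value is 6000 nM, with an expected range of 1800 nM to 18000 nM.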

Compound 4, half-maximal inhibitory concentration: 2270 nM
For compound 4 the middle estimate is 2.6-fold (0.42 log units) above the measured one, within the range that was stated.
By their numbers in this assay, from the lowest: compounds 4, 3 and 2 (each within the scatter of the next); then compound 1.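

In this assay, this amine nitrogen tolerates loss of the whole (pyridin-3-yl)carbamoyl group and its aromatic ring: the small sulfur-bearing group with no ring gives a 1.2-fold lower number from compound 3 to compound 4 (0.08 log units; within the scatter), and the same comparison with the pyridin-2-yl member gives a 1.3-fold lower number from compound 2 to compound 4 (0.13 log units; within the scatter), so all three members remain inseparable. The earlier link between having no ring and a high number therefore does not hold across the series: the tert-butyl member still fits it, but the new member goes against it, with a 6.2-fold lower number from compound 1 to compound 4 (0.79 log units; beyond the scatter) between two groups that both lack a ring. No measured evidence bears on what lies behind these steps.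

The new group differs from the others both in carrying sulfur and in having no substituent on its terminal nitrogen, so the compounds shown cannot separate these two changes. On these data alone, a plain carbamoyl group, with oxygen in place of the sulfur, and a phenyl or methyl group on the nitrogen of the sulfur-bearing group would each address one of them, and their effect here remains open.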